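This account rests on a few compounds, and the source may have more. Where it says the series, first, only, none or still open, it means among the compounds named here.

The series shares a core in which an imidazoline-bearing ether sits on a benzene ring, with variation in the group carried on the neighbouring aromatic carbon. In a functional assay for activation of Alpha-1D adrenergic receptor (Homo sapiens), read by calcium flux (on this read-out lower numbers stand for an effect already at smaller amounts and higher numbers for an effect only at larger amounts of compound), compound 1, with the structure `CCN(CC)C(=O)c1ccccc1OCC1=NCCN1`, gives only a limit of < 5020 nM rather than a number. Compound 2, built as `Cc1cccnc1-c1ccccc1OCC1=NCCN1`, likewise gives only a limit of < 100000 nM in this assay. Among the measured compounds shown here, compound 3, built as `c1ccc(-c2ccoc2)c(OCC2=NCCN2)c1`, is therefore the only member with a real number, at 5.01 nM in this assay; the other two values sit at the limit of < 5020 nM in this assay, at which 1 of the 3 values shown sits, and at the limit of < 100000 nM in this assay, at which 1 of the 3 values shown sits.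

Compound 4, with the structure `Cc1cc(-c2ccccc2OCC2=NCCN2)sn1`, has not yet been measured. It differs from compound 3 by 3-methyl-1,2-thiazol-5-yl in place of furan-3-yl on an aromatic carbon. For the measured compounds named here, no step between measured compounds is available to calibrate such a change, so the expectation rests on the single number for compound 3 alone. The account expects the step of a 3.0-fold higher number from compound 3 to compound 4 (0.48 log units; beyond the scatter) to be modest and toward weaker activation, possibly no more than the usual scatter. On that basis compound 4 is estimated at 15 nM in this assay, with a range from 2.5 nM to 100 nM.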

Compound 4, half-maximal effective concentration: < 100000 nM
Compound 4: a limit, no number; the forecaster's own chance of this, stated with the estimate: 10%; the middle value does not contradict the limit.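

Among the compounds shown here, compound 4 gives only a limit, < 100000 nM, not a number, so no step from compound 3 to this compound can be read. The compounds shown leave open how far 3-methyl-1,2-thiazol-5-yl in place of furan-3-yl actually shifts activation of this receptor.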